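Hydrazone series: a second chloro on the terminal ring

The source may report more compounds than this note shows. Statements on the series, on what has been measured and on what is new or still open speak of the compounds shown alone.

Measured so far in a functional assay on NCI-H460 cells (Homo sapiens) for cytotoxicity, read by MTT assay, with a stated time of 72 h; a lower number here means a stronger inhibitor, a higher number a weaker inhibitor:
compound 1 `CN(C)CCn1cnnc1-c1cc(Oc2ccc(NC(=O)N/N=C/c3ccc(Cl)cc3)cc2F)ccn1`: 320 nM
compound 2 `CN(C)CCn1cnnc1-c1cc(Oc2ccc(NC(=O)N/N=C/c3ccc(O)cc3)cc2F)ccn1`: 1780 nM
compound 3 `CN(C)CCn1cnnc1-c1cc(Oc2ccc(NC(=O)N/N=C/c3ccc(F)cc3)cc2F)ccn1`: 1980 nM

Compound 1 stands lowest of the three numbers in this assay. Its steps to the other two are both beyond the scatter: a 5.6-fold higher number from compound 1 to compound 2 (0.75 log units; beyond the scatter) and a 6.2-fold higher number from compound 1 to compound 3 (0.79 log units; beyond the scatter). Between compound 2 and compound 3 the step of a 1.1-fold higher number from compound 2 to compound 3 (0.05 log units; within the scatter) is within the scatter.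

Compound 4 `CN(C)CCn1cnnc1-c1cc(Oc2ccc(NC(=O)N/N=C/c3ccc(Cl)cc3Cl)cc2F)ccn1` has not yet been measured. It differs from compound 1 as follows: chloro in place of hydrogen on an aromatic carbon. Cut one bond further out, this reads 4-chlorophenyl to 2,4-dichlorophenyl.

For the measured compounds named here, none of the measured steps bears on this change directly: all three swap the one group already present on the terminal ring, while compound 4 keeps that chloro and adds a second one. The shared core is unchanged throughout. Going by the values given here, with no step of the same kind to lean on, no change beyond the scatter is expected in this assay, and the estimate stays close to compound 1, that is no change at the digits printed from compound 1 to compound 4 (within the scatter). Compound 4 is therefore expected at 320 nM, with a range from 110 nM to 950 nM.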

Compound 4, half-maximal inhibitory concentration: 130 nM
Compound 4: the middle estimate sits 2.5-fold (0.39 log units) above what was measured, within the range that was stated.
By their numbers in this assay, from the lowest: compound 4; then compound 1; then compounds 2 and 3 (each within the scatter of the next).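

In this assay, for the compounds shown here, the terminal ring accepts a chloro ortho to a large group with a gain, a 2.5-fold lower number from compound 1 to compound 4 (0.39 log units; beyond the scatter), whereas the earlier steps only exchanged the one group already on that ring. Compound 4 has the lowest number of the four, and the whole-group replacements a 15-fold lower number from compound 3 to compound 4 (1.18 log units; beyond the scatter) and a 14-fold lower number from compound 2 to compound 4 (1.14 log units; beyond the scatter) are large, though each of these changes two places on the ring and cannot be assigned to either one alone. Nothing at hand accounts for the added chloro's effect.

The compounds shown leave open whether the gain is specific to chloro or would also appear with a methyl, a methoxy or a bromo at this position. They also leave open whether this chloro would give a gain alone, as a 2-chlorophenyl group without the chloro of compound 1.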